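The compounds below may be only part of what the source reports. "The series", "measured", "known", "first", "only" and "open" are said of these compounds alone.

Measured so far in a functional assay on HL-60 cells (Homo sapiens) for cytotoxicity, read by luminescence and CellTiter-Glo, with a stated time of 3 days; a lower number here means a stronger inhibitor, a higher number a weaker inhibitor:
- compound 1 `N#Cc1ccc(NC(=O)c2cc(-c3ccncc3)ccc2O)cc1` gives 5410 nM
- compound 2 `N#Cc1ccc(NC(=O)c2cc(Cc3ccccc3)ccc2O)cc1` gives 1740 nM

Compound 2 holds the lower of the two numbers (1740 nM). Next is compound 3 `N#Cc1ccc(NC(=O)c2cc(C(F)(F)F)ccc2O)cc1`, with trifluoromethyl in place of benzyl on an aromatic carbon, para to a hydroxy group (trifluoromethyl in place of benzyl on an aromatic carbon). Within the data shown here, the one measured step at this place is modest (a 3.1-fold lower number from compound 1 to compound 2 (0.49 log units; beyond the scatter)), and no measured compound carries trifluoromethyl, so the direction stays open. On that modest step, the expected change is small, within the scatter (a 1.1-fold higher number from compound 2 to compound 3 (0.06 log units; within the scatter)). For compound 3 the estimated value is 2000 nM (expected range 500 nM to 8000 nM).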

Compound 3, half-maximal inhibitory concentration: 3120 nM
Estimate against measurement, compound 3: 1.6-fold (0.19 log units) below, within the range that was stated.
By their numbers in this assay, from the lowest: compounds 2, 3 and 1 (each within the scatter of the next, the first and the last beyond it).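

In this assay, trifluoromethyl, which has no ring, cannot be separated from benzyl (a 1.8-fold higher number from compound 2 to compound 3 (0.25 log units; within the scatter)) or from pyridin-4-yl (a 1.7-fold lower number from compound 1 to compound 3 (0.24 log units; within the scatter)) at the position para to a hydroxy group. A ring at this position is therefore not needed for a value in this range. Compound 3 stays within the scatter of both compound 1 and compound 2, although those two lie beyond the scatter of each other, so the three groups give no clear order.

As far as these compounds go, whether an amine, a carboxylic acid or a longer alkyl chain here would move the value beyond the scatter remains open. No available evidence accounts for these values.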